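Iodo for Fluoro on the Fused Ring of Compound 3

A few compounds are considered here, and "the series" means these few. Any claim that something is new, unique, unknown or untested is made for them only; others in the source may bear on it.

Measured compounds:
compound 1, `CC(C)(C)c1cc(NC(=O)Nc2ccc(-c3cn4cccnc4n3)cc2)no1`; in a functional assay on MV4-11 cells (Homo sapiens) for cytotoxicity, read by MTT assay, with a stated time of 72 h (a lower number here means a stronger inhibitor, a higher number a weaker inhibitor), compound 1 gives 171 nM
compound 2, `CC(C)(C)c1cc(NC(=O)Nc2ccc(-c3cn4ccncc4n3)cc2)no1`; in this assay compound 2 gives 44.8 nM
compound 3, `CC(C)(C)c1cc(NC(=O)Nc2ccc(-c3cn4cc(F)ccc4n3)cc2)no1`; in this assay compound 3 gives 20.9 nM

Among the three, compound 3 gives the lowest number, compound 2 a higher one and compound 1 the highest. Among the measured compounds shown here, the one measured step, a 3.8-fold lower number from compound 1 to compound 2 (0.58 log units; beyond the scatter), swaps the whole fused bicycle and says nothing about a substituent on it.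

Compound 4, `CC(C)(C)c1cc(NC(=O)Nc2ccc(-c3cn4cc(I)ccc4n3)cc2)no1`, differs from compound 3 by iodo in place of fluoro on an aromatic carbon. For the measured compounds named here, no measured pair changes only a halogen on that ring, so no step bears directly on this move. With compound 3 as the starting point and no guidance either way, the expected change is a 1.1-fold higher number from compound 3 to compound 4 (0.02 log units; within the scatter), no larger than the scatter. Compound 4 is therefore estimated at 22 nM in this assay, within a range from 8 nM to 60 nM.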

Compound 4, half-maximal inhibitory concentration: 98.6 nM
The estimate for compound 4 lay 4.5-fold (0.65 log units) below the measured number, outside the stated range (above it).
By their numbers in this assay, from the lowest: compound 3; then compound 2; then compounds 4 and 1 (each within the scatter of the next).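

Among the compounds shown here, this is the first step that changes only the halogen at this position, and a 4.7-fold higher number from compound 3 to compound 4 (0.67 log units; beyond the scatter) shows that in this assay the position is sensitive to which halogen it carries. The swap exchanges one heavy atom for one heavy atom, with no change in the counts of hydrogen-bond donors or acceptors or in net charge, so those counts do not separate compound 3 from compound 4, yet the two numbers differ beyond the scatter. Nothing at hand accounts for the size or direction of this step.

On these data alone, with only fluoro and iodo at this position, it remains open whether chloro or bromo would fall nearer to compound 3 or to compound 4. As far as these compounds go, it is equally open how a methoxy group, an amine or plain hydrogen there would compare with fluoro.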